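Swapping the aryl amide in a trifluoromethyl aniline series

The source may hold more compounds than are shown below. What is called first, only, known or untested is meant among the compounds shown, and "the series" means these compounds.

Compound 3, `O=C(Nc1cc(C(F)(F)F)ccc1N1CCCCC1)c1ccccc1`, is the starting point. In a functional assay on HL-60 cells (Homo sapiens) for cytotoxicity, read by MTT assay, with a stated time of 48 h (on this read-out lower numbers stand for stronger inhibition and higher numbers for weaker inhibition), compound 3 gives "not active" (no number reported), so no single number places it on the scale, and its position can only be described as inactive under the conditions used. Compound 4, `O=C(Nc1cc(C(F)(F)F)ccc1N1CCCCC1)c1cccnc1Cl`, differs from it in one place: 2-chloropyridin-3-yl in place of phenyl on a carbonyl carbon.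

Among the measured compounds shown here, none of the measured steps covers this exact change. For the measured compounds named here, the one step that was measured, a 5.9-fold higher number from compound 1 to compound 2 (0.77 log units; beyond the scatter), concerns the amino substituent on the shared core and not the group on the carbonyl carbon, so it does not speak directly to the step from compound 3 to compound 4. What the data do show is that both measured compounds carry the 2-chloropyridin-3-yl amide. Compound 1, `O=C(Nc1cc(C(F)(F)F)ccc1Nc1ccc(Br)cc1)c1cccnc1Cl`, gives 14200 nM in this assay, and compound 2, `CCN(CC)c1ccc(C(F)(F)F)cc1NC(=O)c1cccnc1Cl`, gives 84100 nM. Compound 2, with its diethylamino group, is the closer analogue of compound 4.

Going by the values given here, since compound 3 has no number, no size of step can be stated for this assay; the expectation rests on compound 2 alone. Compound 4 is therefore expected to give 60000 nM, with a range from 15000 nM to 200000 nM, and a real chance that only a limit is reported.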

Compound 4, half-maximal inhibitory concentration: "not active" (no number reported)
Compound 4 has no reported number here; there is nothing to compare the estimate with.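

In this assay, among the compounds shown here, compound 3 and compound 4 are both reported as not active, with no number for either, so no step between them can be read. Nothing available bears on this result. The compounds shown leave open whether 2-chloropyridin-3-yl in place of phenyl on a carbonyl carbon changes the read-out at all.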